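This account rests on a few compounds, and the source may have more. Where it says the series, first, only, none or still open, it means among the compounds named here.

Series around a shared core, all tested in a toxicity assay on Vero cells (Chlorocebus sabaeus) for cytotoxicity; a lower number here means that less compound is tolerated, a higher number that more compound is tolerated. Compound 1 `COc1ncc(-c2ccccc2)cc1[C@@H](c1ccccc1)[C@@](O)(CCN(C)C)c1cc(F)ccc1F` reaches only the assay limit, > 50 ug/mL. Compound 2 `COc1ncc(-c2ccccc2)cc1[C@@H](c1ccccc1)[C@@](O)(CCN(C)C)c1cc(F)cc(F)c1` likewise reports a limit, > 50 ug/mL. The step that the two limits leave unreadable from compound 1 to compound 2 is therefore of unreadable size. Compound 3 `COc1nc(-c2ccc(F)cc2)ccc1[C@@H](c1ccccc1)[C@@](O)(CCN(C)C)c1cccc2ccccc12` also stands at a limit in this assay, > 50 ug/mL. For the measured compounds named here, all three values sit at the limit of > 50 ug/mL in this assay, at which 3 of the 3 values shown sit, so no measured step offers a readable size and compound 3 cannot be placed relative to the others. Compound 4 `COc1nc(-c2ccc(Cl)cc2)ccc1[C@@H](c1ccccc1)[C@@](O)(CCN(C)C)c1cccc2ccccc12` carries the change (chloro in place of fluoro on an aromatic carbon), chloro in place of fluoro on an aromatic carbon. Going by the values given here, no measured step bears on this change. The step that the limit leaves unreadable from compound 3 to compound 4 is expected to stay within the scatter, most likely again at a limit. Compound 4 is estimated at 60 ug/mL (range 30 ug/mL to 120 ug/mL).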

Compound 4, half-maximal cytotoxic concentration: > 50 ug/mL
Compound 4: a limit, no number; the forecaster's own chance of this, stated with the estimate: 80%; the middle value is on the limit's open side.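

No size can be read for the change from 4-fluorophenyl to 4-chlorophenyl, as compound 3 and compound 4 both give only a limit in this assay: the limit of > 50 ug/mL in this assay, at which 4 of the 4 values shown sit.

The compounds shown leave open where the actual half-maximal cytotoxic concentration of any of the four lies, and whether this change shifts it.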